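Adding 4-ethylpiperazin-1-yl to compound 3

The source may report more compounds than this note shows. Statements on the series, on what has been measured and on what is new or still open speak of the compounds shown alone.

In an ADME assay on BaF3 cells (Mus musculus) for antiproliferative activity, read by CCK-8 assay, with a stated time of 72 h (on this read-out lower numbers stand for stronger inhibition of growth and higher numbers for weaker inhibition of growth), compound 1 (`O=C(CCSc1ccc2c(/C=C/c3ccccn3)n[nH]c2c1)Nc1cccc(C(F)(F)F)c1`) gives 2300 nM. Compound 2 (`Cc1ccc(NC(=O)CCSc2ccc3c(/C=C/c4ccccn4)n[nH]c3c2)cc1`) gives > 10000 nM, which is a limit of the assay. Among the compounds with values here, compound 3 (`Cc1ccc(NC(=O)CCSc2ccc3c(/C=C/c4ccccn4)n[nH]c3c2)cc1C(F)(F)F`) gives 530 nM, the lowest number so far. It stands out in a 4.3-fold lower number from compound 1 to compound 3 (0.64 log units; beyond the scatter) and in an at least 18-fold lower number from compound 2 to compound 3 (1.27 log units; beyond the scatter), while the remaining measured step is an at least 4.3-fold higher number from compound 1 to compound 2 (0.63 log units; beyond the scatter).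

Compound 4 (`CCN1CCN(Cc2ccc(NC(=O)CCSc3ccc4c(/C=C/c5ccccn5)n[nH]c4c3)cc2C(F)(F)F)CC1`) differs from compound 3 by 4-ethylpiperazin-1-yl in place of hydrogen on a saturated chain carbon bound to an aromatic carbon. Within the data shown here, no measured step tests this group. The closest guide is the methyl gain in compound 3, a 4.3-fold lower number from compound 1 to compound 3 (0.64 log units; beyond the scatter), so a modest further fall is expected, held loosely: a 2.7-fold lower number from compound 3 to compound 4 (0.42 log units; beyond the scatter). Compound 4 is estimated at 200 nM, within an expected range of 40 nM to 1200 nM.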

Compound 4, concentration for 50% growth inhibition: 840 nM
Estimate against measurement, compound 4: 4.2-fold (0.62 log units) below; the measured number falls inside the stated range.
By their numbers in this assay, from the lowest: compounds 3 and 4 (each within the scatter of the next); then compound 1. At a limit, above all of these: compound 2.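

In this assay the step is a 1.6-fold higher number from compound 3 to compound 4 (0.20 log units; within the scatter), so this saturated chain carbon bound to an aromatic carbon takes 4-ethylpiperazin-1-yl, with its six-membered non-aromatic ring, without a change beyond the scatter. The substituted compound also keeps a measurable edge, with a 2.7-fold lower number from compound 1 to compound 4 (0.44 log units; beyond the scatter). Nothing measured in the data shown bears on why this group is tolerated.

From the compounds shown here alone, whether a morpholine, a piperidine or a dimethylamine would read the same in place of 4-ethylpiperazin-1-yl remains open. So does the effect of a longer chain carrying the piperazine.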